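Capping a Free Hydroxyl Group With a Benzyl

This account rests on a few compounds, and the source may have more. Where it says the series, first, only, none or still open, it means among the compounds named here.

Compound 2 `CN1CCN(CCCCOc2c(O)cc3oc(-c4ccccc4)cc(=O)c3c2O)CC1` has, in a functional assay on A549 cells (Homo sapiens) for antiproliferative activity, read by MTT assay, with a stated time of 48 h (on this read-out higher numbers stand for weaker inhibition and lower numbers for stronger inhibition), a number that is only a limit of the assay, > 100000 nM. Compound 1 `COc1cc2oc(-c3ccccc3)cc(=O)c2c(O)c1OCCCCN1CCN(C)CC1`, which differs only by a methyl on that oxygen, gives 32000 nM in this assay. For the measured compounds named here, the single measured step, an at least 3.1-fold higher number from compound 1 to compound 2 (0.49 log units; beyond the scatter), shows that uncovering the hydroxyl weakened inhibition, one end of it sitting at the limit of > 100000 nM in this assay, at which 1 of the 2 values shown sits. Compound 3 `CN1CCN(CCCCOc2c(OCc3ccccc3)cc3oc(-c4ccccc4)cc(=O)c3c2O)CC1` carries benzyl in place of hydrogen on an oxygen on an aromatic ring, covering the oxygen again. The reverse direction is expected: compound 3 is expected to give a lower number, an at least 3.3-fold lower number from compound 2 to compound 3 (0.52 log units; beyond the scatter). Compound 3 is estimated at 30000 nM, between 8000 nM and 100000 nM.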

Compound 3, half-maximal inhibitory concentration: 4400 nM
Compound 3: middle estimate off by 6.8-fold (0.83 log units), on the high side; the whole stated range lies above it.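

On this oxygen, the choice of cover matters: in this assay, benzyl in place of hydrogen gives an at least 22-fold lower number from compound 2 to compound 3 (1.35 log units; beyond the scatter) as its step, the largest change seen so far. Benzyl also outdoes methyl, with a 7.3-fold lower number from compound 1 to compound 3 (0.86 log units; beyond the scatter) as the step, so covering the hydroxyl is not all that counts. The first of these steps gives only a minimum size, as compound 2 carries a limit: (the limit of > 100000 nM in this assay, at which 1 of the 3 values shown sits). Going by these compounds, how an ethyl or a 4-fluorobenzyl on this oxygen would compare stays open.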